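Series notes: methyl on the saturated ring, cyano analogue

The source may hold more compounds than are shown below. What is called first, only, known or untested is meant among the compounds shown, and "the series" means these compounds.

Measured so far in a functional assay on the whole organism with Rattus norvegicus as the target; a lower number here means that less compound is needed, a higher number that more compound is needed for the effect:
compound 1 `Cc1ccccc1OCC(O)CNCC(=O)Nc1ccc(C2=NNC(=O)CC2)cc1` gives 2 umol/kg
compound 2 `Cc1ccccc1OCC(O)CNCC(=O)Nc1ccc(C2=NNC(=O)CC2C)cc1` gives 2.7 umol/kg
compound 3 `N#Cc1ccccc1OCC(O)CNCC(=O)Nc1ccc(C2=NNC(=O)CC2)cc1` gives 14 umol/kg

Two single-point changes connect the measured compounds. Compound 1 and compound 2 differ by methyl in place of hydrogen on a saturated ring carbon; the step in this assay is a 1.4-fold higher number from compound 1 to compound 2 (0.13 log units; within the scatter), so the two values cannot be told apart. Compound 1 and compound 3 differ by cyano in place of methyl on an aromatic carbon; the step is a 7.0-fold higher number from compound 1 to compound 3 (0.85 log units; beyond the scatter), and compound 3 carries the highest number of the three, beyond the scatter from both others.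

Compound 4 `CC1CC(=O)NN=C1c1ccc(NC(=O)CNCC(O)COc2ccccc2C#N)cc1` is not yet measured. It differs from compound 3 by methyl in place of hydrogen on a saturated ring carbon. This is the same change as that from compound 1 to compound 2: the place is described in the same words in both cases. The two cores differ from one another as compound 1 differs from compound 3, described above.

Going by the values given here, the single measured instance of this change is a 1.4-fold higher number from compound 1 to compound 2 (0.13 log units; within the scatter), within the scatter. The expectation for compound 4 rests on that one instance alone, so it is no more than an expectation that a small step repeats on the cyano core. Compound 4 is expected to give a step of a 1.3-fold higher number from compound 3 to compound 4 (0.11 log units; within the scatter) in this assay. The estimate for compound 4 is 18 umol/kg, with the likely range running from 8 umol/kg to 40 umol/kg.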

Compound 4, dose for half-maximal effect: 0.9 umol/kg
The estimate for compound 4 lay 20-fold (1.30 log units) above the measured number; the whole stated range lies above it.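

In this assay the methyl in place of hydrogen on a saturated ring carbon does not carry over from the core of compound 1 to the core of compound 3, where the step is a 16-fold lower number from compound 3 to compound 4 (1.19 log units; beyond the scatter) and stands well apart from the earlier one: the same change on two cores in this assay, a 1.4-fold higher number (0.13 log units; within the scatter) from compound 1 to compound 2 and a 16-fold lower number (1.19 log units; beyond the scatter) from compound 3 to compound 4, 21-fold (1.32 log units) apart, beyond the scatter of two such steps.
Read the other way, cyano in place of methyl on an aromatic carbon also changes direction once the ring methyl is present, the step now being a 3.0-fold lower number from compound 2 to compound 4 (0.48 log units; beyond the scatter) and no longer a rise in the number: the same change on two cores in this assay, a 7.0-fold higher number (0.85 log units; beyond the scatter) from compound 1 to compound 3 and a 3.0-fold lower number (0.48 log units; beyond the scatter) from compound 2 to compound 4, 21-fold (1.32 log units) apart, beyond the scatter of two such steps.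
The two changes therefore do not add up across these four compounds, so a step measured on one core is a poor guide to the other here, but a single set of four compounds shows neither why this happens nor whether it holds for any other pair of groups.

Open, from the compounds shown here alone, is whether a methoxy group or a chlorine atom in place of the nitrile on the aromatic carbon would follow cyano or methyl when the ring methyl is present. Equally open, going by these compounds, is whether an ethyl group on the saturated ring carbon would repeat the small step on the core of compound 1 and the large one on the core of compound 3.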